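Chloro to Fluoro Exchange Across Two Related Cores

This account rests on a few compounds, and the source may have more. Where it says the series, first, only, none or still open, it means among the compounds named here.

Compound 1, `Cc1ccc(Cn2c(/C=C3\SC(=S)N(CC(=O)O)C3=O)nc3ccc(Cl)cc32)cc1`, gives 1520 nM in a functional assay on PC-3 cells (Homo sapiens) for cytotoxicity, read by MTT assay, with a stated time of 48 h; on this read-out lower numbers stand for stronger inhibition and higher numbers for weaker inhibition.
Compound 2, `Cc1ccc(Cn2c(/C=C3\SC(=S)N(CC(=O)O)C3=O)nc3ccc(F)cc32)cc1`, gives 5820 nM in this assay.
Compound 3, `O=C(O)CN1C(=O)/C(=C/c2nc3cc(Cl)ccc3n2Cc2ccccc2F)SC1=S`, gives 3480 nM in this assay.

The three measured compounds share a common skeleton and differ at two sites. Compound 1 and compound 2 differ only by fluoro in place of chloro on an aromatic carbon, and that single exchange produced a 3.8-fold higher number from compound 1 to compound 2 (0.58 log units; beyond the scatter) in this assay. Compound 3 carries a different substituent on its pendant benzyl ring; the difference between its core and the core of compound 1 is not broken down here. The values of compound 3 and compound 2 lie within the scatter of each other, so no order between them is claimed, while compound 3 stands beyond the scatter from compound 1.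

Compound 4, `O=C(O)CN1C(=O)/C(=C/c2nc3cc(F)ccc3n2Cc2ccccc2F)SC1=S`, has not yet been measured. Going by the values given here, it differs from compound 3 by fluoro in place of chloro on an aromatic carbon, which is the same change, at the same place, as the one separating compound 1 from compound 2. Because the earlier exchange gave a 3.8-fold higher number from compound 1 to compound 2 (0.58 log units; beyond the scatter), compound 4 is expected to show a 3.2-fold higher number from compound 3 to compound 4 (0.50 log units; beyond the scatter) in this assay, a step of similar size and direction. This rests on one measured pair only, so a somewhat smaller step would not surprise. Compound 4 is therefore estimated at 11000 nM, with a plausible range from 5000 nM to 28000 nM.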

Compound 4, half-maximal inhibitory concentration: > 50000 nM
Compound 4 ended at the assay's limit; the forecaster's own chance of this, stated with the estimate: 10%; at least 4.5-fold (0.65 log units) between middle value and limit.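

In this assay, fluoro in place of chloro on an aromatic carbon moved the number in the same direction on the second core, giving an at least 14-fold higher number from compound 3 to compound 4 (1.15 log units; beyond the scatter), but the step did not keep its size from one core to the other: the same change on two cores in this assay, a 3.8-fold higher number (0.58 log units; beyond the scatter) from compound 1 to compound 2 and an at least 14-fold higher number (1.15 log units; beyond the scatter) from compound 3 to compound 4, at least 3.7-fold (0.57 log units) apart, beyond the scatter of two such steps

Compound 4 stands at a limit of the assay and not at a number, so its step has a lower bound and no upper one: the limit of > 50000 nM in this assay, at which 1 of the 4 values shown sits.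

The two pairs therefore show that the direction of this exchange carried over between these two cores and that the size measured on one core did not transfer to the other, yet they do not show why the steps differ, how large the step from compound 3 to compound 4 truly is, or that any rule holds beyond these four compounds.

The compounds shown leave open whether bromo, methyl or methoxy on the same aromatic carbon would give a graded series on either core, or whether the exchange would behave in the same way on a pendant benzyl ring with no substituent at all. They also leave open whether the difference between the two steps would persist if the carboxylic acid gave way to an amide or an ester.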